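The source may hold more compounds than are shown below. What is called first, only, known or untested is meant among the compounds shown, and "the series" means these compounds.

Of the compounds shown here, two with a shared core have been measured. Compound 1 `Cc1ccc(CNC(=O)CCN(Cc2ccc(C(=O)NO)cc2)C(=O)c2ccc(N(C)C)cc2)cc1` gives 14.4 nM in an assay on Sf9 cells for inhibition of protein deacetylase HDAC6 (Homo sapiens), read by fluorescence, with stated times of 90 min and 30 min (a higher number here means a weaker inhibitor, a lower number a stronger inhibitor), the lowest of the two numbers seen. Compound 2 `COc1cc(OC)cc(C(=O)N(CCC(=O)NCc2ccccc2)Cc2ccc(C(=O)NO)cc2)c1` gives 26 nM in this assay, and this lies within the scatter of compound 1, so the two cannot be told apart.

Compound 3 `CN(C)c1ccc(C(=O)N(CCC(=O)NCc2ccc(Cl)cc2)Cc2ccc(C(=O)NO)cc2)cc1` has not yet been measured. It differs from compound 1 in one place: chloro in place of methyl on an aromatic carbon, on an aromatic carbon of a six-membered aromatic ring of carbon only, para to a large group. Seen one bond further out, a 4-methylbenzyl becomes a 4-chlorobenzyl.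

Among the measured compounds shown here, no measured pair shows this exchange, so no step size is known for it. For compound 3 the expected step of a 1.0-fold higher number from compound 1 to compound 3 (0.02 log units; within the scatter) is one that stays within the scatter, with no clear direction. Compound 3 is therefore estimated at 15 nM, within a range from 6 nM to 40 nM.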

Compound 3, half-maximal inhibitory concentration: 10 nM
Compound 3: middle estimate off by 1.5-fold (0.18 log units), on the high side; measured number inside the range.
By their numbers in this assay, from the lowest: compounds 3, 1 and 2 (each within the scatter of the next, the first and the last beyond it).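

In this assay, chloro in place of methyl on this aromatic carbon gives a 1.4-fold lower number from compound 1 to compound 3 (0.16 log units; within the scatter), so the 4-methylbenzyl and 4-chlorobenzyl compounds cannot be told apart. Among the compounds shown here, this is the first pair that differs in one place only, and it shows that this position can carry either group with no difference the measurement can resolve. No further data bear on this result, so nothing can be said about why the two groups read alike.

As far as these compounds go, both groups are small and single-atom at the point of attachment, so it remains open whether a larger or very different group at this place, such as a methoxy, an amine or a carboxylic acid, would also leave the number unmoved. For the compounds shown here, the exchange is also seen only on the core of compound 1, so whether it behaves the same on another core stays unknown.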